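Chloro for hydrogen on the anilide ring

A few compounds are considered here, and "the series" means these few. Any claim that something is new, unique, unknown or untested is made for them only; others in the source may bear on it.

Compound 1 `O=C(Nc1ccccc1)c1ccc(/N=N\c2c[nH]c3ccccc23)cc1` gives 103000 nM in a functional assay on HCT-116 cells (Homo sapiens) for inhibition, read by MTT assay, with a stated time of 72 h; a lower number here means a stronger inhibitor, a higher number a weaker inhibitor. For the measured compounds named here, of the two numbers so far it is the lower one; compound 2 `O=C(Nc1ccc([N+](=O)[O-])cc1)c1ccc(/N=N\c2c[nH]c3ccccc23)cc1` gives 156000 nM in this assay, and the two lie within the scatter of each other. Going by the values given here, the only measured step, a 1.5-fold higher number from compound 1 to compound 2 (0.18 log units; within the scatter), put nitro in place of hydrogen on an aromatic carbon and moved the number by no more than the scatter. Compound 3 `O=C(Nc1ccc(Cl)cc1)c1ccc(/N=N\c2c[nH]c3ccccc23)cc1` differs from compound 1 by chloro in place of hydrogen on an aromatic carbon. This change falls at the place where the nitro step was made, and that nitro step is the only one that bears on it. A step within the scatter is therefore expected in this assay, with no set direction. Compound 3 is estimated at 110000 nM, in the range 50000 nM to 250000 nM, the expected step being a 1.1-fold higher number from compound 1 to compound 3 (0.03 log units; within the scatter).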

Compound 3, half-maximal inhibitory concentration: 187000 nM
The estimate for compound 3 lay 1.7-fold (0.23 log units) below the measured number, within the range that was stated.
By their numbers in this assay, from the lowest: compounds 1, 2 and 3 (each within the scatter of the next).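

In this assay, chloro on this aromatic carbon, para to a large group, gives a 1.8-fold higher number from compound 1 to compound 3 (0.26 log units; within the scatter) and, set against nitro at the same place, gives a 1.2-fold higher number from compound 2 to compound 3 (0.08 log units; within the scatter). With chloro added to nitro, two quite different groups have now been placed here, and neither step leaves the scatter, so compounds 1, 2 and 3 cannot be put in any order at this position. No measurement among the data accounts for these numbers.

As far as these compounds go, whether an amine, a carboxylic acid or a longer alkyl chain in place of chloro would move the number beyond the scatter stays open. Also open, from the compounds shown here alone, is whether a change on the shared core, rather than on this six-membered ring, would do so.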